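A few compounds are considered here, and "the series" means these few. Any claim that something is new, unique, unknown or untested is made for them only; others in the source may bear on it.

Compound 1 `CCCCC(C)C[C@]1(CC)O[C@H]1[C@]1(CC)C=CC(=O)O1` gives > 100000 nM. Compound 2 `CCCCC(C)CC(O)(/C=C(/CC)[C@@H](O)CC(=O)OC)CC` gives > 100000 nM. Compound 3 `CCCCC(CC)CC(O)(/C=C(/CC)[C@@H](O)CC(=O)OC)CC` gives > 100000 nM.

In a functional assay on Bel-7402 cells (Homo sapiens) for cytotoxicity, read by MTT assay, with a stated time of 72 h (on this read-out higher numbers stand for weaker inhibition and lower numbers for stronger inhibition), each of these values is a limit of the assay and not a number; all three sit at the limit of > 100000 nM in this assay, at which 3 of the 3 values shown sit. The change methyl in place of hydrogen on a saturated chain carbon, four bonds along the chain from a double-bonded chain carbon and an oxygen on a saturated carbon therefore yields a step that the two limits leave unreadable from compound 2 to compound 3. The difference between the core of compound 1 and the core of compound 2 is not broken down here.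

Compound 4 `CCCCC(CC)C[C@]1(CC)O[C@H]1[C@]1(CC)C=CC(=O)O1` is not yet measured. It differs from compound 1 by methyl in place of hydrogen on a saturated chain carbon, three bonds along the chain from a saturated ring carbon, the same kind of change as that from compound 2 to compound 3, though the place differs: there it is four bonds along the chain from a double-bonded chain carbon and an oxygen on a saturated carbon, here three bonds along the chain from a saturated ring carbon. Since compound 1 sits at the limit (the limit of > 100000 nM in this assay, at which 3 of the 3 values shown sit), and the earlier step that the two limits leave unreadable from compound 2 to compound 3 cannot be sized, the expected step is a step that the limit leaves unreadable from compound 1 to compound 4. Compound 4 is estimated at 150000 nM, between 40000 nM and 600000 nM.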

Compound 4, half-maximal inhibitory concentration: > 100000 nM
Compound 4: no number, only a limit; the forecaster's own chance of this, stated with the estimate: 85%; the middle value does not contradict the limit.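

In this assay compound 1 and compound 4 give limits and not numbers, so no step can be read between them: the limit of > 100000 nM in this assay, at which 4 of the 4 values shown sit. The compounds shown leave open how strongly any of them inhibits these cells, and whether methyl in place of hydrogen changes that at all.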